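The compounds below may be only part of what the source reports. "The series", "measured", "known", "first", "only" and "open" are said of these compounds alone.

For the measured compounds named here, compound 1 `CCN(CC)C/C1=C/C[C@](C)(CCC=C(C)C)/C=C/[C@@H](OC(=O)C=C(C)C)[C@](C)(O)/C=C/C1=O` and compound 2 `CC(C)=CCC[C@]1(C)/C=C/[C@@H](OC(=O)C=C(C)C)[C@](C)(O)/C=C/C(O)/C(C=O)=C\C1` are the two measured members. In a functional assay on SMMC-7721 cells (Homo sapiens) for antiproliferative activity, read by MTT assay, with a stated time of 48 h (a higher number here means a weaker inhibitor, a lower number a stronger inhibitor), compound 1 gives 570 nM, and compound 2 gives 730 nM; the two numbers sit within the usual scatter of each other, so neither stands apart. Compound 3 `CCN(CC)C(=O)/C1=C/C[C@](C)(CCC=C(C)C)/C=C/[C@@H](OC(=O)C=C(C)C)[C@](C)(O)/C=C/C1=O` has yet to be measured. Compound 3 differs from compound 1 by diethylcarbamoyl in place of (diethylamino)methyl on a double-bonded ring carbon on the shared core. Going by the values given here, no measured pair isolates such a change, so the step is expected to be a 1.4-fold higher number from compound 1 to compound 3 (0.15 log units; within the scatter), a small weakening at most and not clearly beyond the scatter. Compound 3 is therefore estimated at 800 nM, with a range of 350 nM to 1800 nM.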

Compound 3, half-maximal inhibitory concentration: 13800 nM
Beside the measured number, compound 3's estimate is 17-fold (1.24 log units) below it; the whole stated range lies below it.
By their numbers in this assay, from the lowest: compounds 1 and 2 (each within the scatter of the next); then compound 3.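

Placing diethylcarbamoyl in place of (diethylamino)methyl on this double-bonded ring carbon gives a 24-fold higher number from compound 1 to compound 3 (1.38 log units; beyond the scatter) in this assay, so activity here depends strongly on the group's identity, which the earlier compounds could not show. The two groups differ only by a carbonyl in place of the carbon bearing the nitrogen. No available evidence explains the size of this step.

From the compounds shown here alone, it remains open whether a cyclic amine such as pyrrolidin-1-ylmethyl, a primary aminomethyl group or a carboxylic acid on this carbon would stay close to compound 1.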